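Replacing the fluoro of compound 1

A few compounds are considered here, and "the series" means these few. Any claim that something is new, unique, unknown or untested is made for them only; others in the source may bear on it.

Measured in a functional assay on HeLa cells (Homo sapiens) for antiproliferative activity, read by CCK-8 assay, with a stated time of 72 h; a higher number here means a weaker inhibitor of growth, a lower number a stronger inhibitor of growth
- compound 1 `CCC1C(=O)N(C)c2cnc(-n3ccc4cc(F)ccc43)nc2N1c1ccn(C)n1` reads "not active" (no number reported)
- compound 2 `CC[C@@H]1C(=O)N(C)c2cnc(Nc3ccc(S(N)(=O)=O)cc3)nc2N1C1CCCC1` reads 317 nM
- compound 3 `CC[C@@H]1C(=O)N(C)c2cnc(Nc3ccc(S(=O)(=O)NC4CCCC4)cc3)nc2N1C1CCCC1` reads 609 nM

Compound 1 has no number to stand on. In this assay, on these data alone, compound 1 is reported only as "not active" (no number reported), so any comparison with it stays open. Compound 4 `CCC1C(=O)N(C)c2cnc(-n3ccc4cc(C(=O)NCC(C)C)ccc43)nc2N1c1ccn(C)n1` keeps the core of compound 1 and carries isobutylcarbamoyl in place of fluoro on an aromatic carbon of a six-membered aromatic ring of carbon only, part of a fused or bridged system of two rings (isobutylcarbamoyl in place of fluoro on an aromatic carbon). Going by the values given here, the only measured step is a 1.9-fold higher number from compound 2 to compound 3 (0.28 log units; within the scatter). That step lies within the scatter and concerns a sulfonamide nitrogen, not this change, so it gives no size to carry over. No step size can therefore be expected here. The one direction open is towards a measurable value, and compound 4 may equally stay without a number. Compound 4 is estimated at 2500 nM, with an expected range from 250 nM to 25000 nM.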

Compound 4, concentration for 50% growth inhibition: 4970 nM
Compound 4: middle estimate off by 2.0-fold (0.30 log units), on the low side; the range from low to high includes it.
By their numbers in this assay, from the lowest: compounds 2 and 3 (each within the scatter of the next); then compound 4.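

Going by these compounds alone, compound 1 has no number while compound 4 has one, so no step between the two can be read. The compounds shown leave open how far isobutylcarbamoyl in place of fluoro moves growth inhibition. Nothing shown bears on the reason for the reading of compound 4.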